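This account rests on a few compounds, and the source may have more. Where it says the series, first, only, none or still open, it means among the compounds named here.

Of the compounds shown here, three built on one shared core have been measured in a functional assay for agonist activity at G protein-coupled receptor 88 (Homo sapiens), read by HTRF and cAMP accumulation; on this read-out lower numbers stand for an effect already at smaller amounts and higher numbers for an effect only at larger amounts of compound. Compound 1 `CC(C)C[C@H](N)CN(C(=O)[C@@H]1C[C@H]1c1ccccc1)c1ccc(-c2ccccc2)cc1` gives 880 nM. Compound 2 `CC(C)C[C@H](N)CN(C(=O)[C@@H]1C[C@H]1c1ccccc1)c1ccc(-c2ccsc2)cc1` gives 1200 nM. Compound 3 `CC(C)C[C@H](N)CN(C(=O)[C@@H]1C[C@H]1c1ccccc1)c1ccc(C2=CCCC2)cc1` gives 1200 nM. The step of a 1.4-fold higher number from compound 1 to compound 2 (0.13 log units; within the scatter) and the step of a 1.4-fold higher number from compound 1 to compound 3 (0.13 log units; within the scatter) both stay within the scatter, and so does the step of no change at the digits printed from compound 2 to compound 3 (within the scatter). Compound 3 therefore stands level with compound 2, the two together holding the highest of the three numbers, and its separation from compound 1 is also within the scatter, so none of the three can be told apart on this read-out.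

Compound 4 `Cc1ccccc1-c1ccc(N(C[C@@H](N)CC(C)C)C(=O)[C@@H]2C[C@H]2c2ccccc2)cc1` has not yet been measured. It differs from compound 3 in one place: 2-methylphenyl in place of cyclopent-1-en-1-yl on an aromatic carbon. The step that bears most on this is the change from compound 1 to compound 3, in which a six-membered aromatic ring gave way to the five-membered non-aromatic ring and the number moved only within the scatter; the change from compound 2 to compound 3 likewise moved nothing. Going back to a six-membered aromatic ring, now carrying a methyl group, is therefore expected to give a step of a 1.2-fold lower number from compound 3 to compound 4 (0.08 log units; within the scatter) that stays within the scatter. The estimate for compound 4 in this assay is 1000 nM, with a range from 400 nM to 2500 nM.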

Compound 4, half-maximal effective concentration: 3400 nM
Beside the measured number, compound 4's estimate is 3.4-fold (0.53 log units) below it; the whole stated range lies below it.
By their numbers in this assay, from the lowest: compounds 1, 2 and 3 (each within the scatter of the next); then compound 4.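

In this assay, for the compounds shown here, phenyl, thiophen-3-yl and cyclopent-1-en-1-yl could not be told apart at this position, on an aromatic carbon para to a large group, but adding one methyl group to the phenyl ring gives the first change beyond the scatter (a 3.9-fold higher number from compound 1 to compound 4 (0.59 log units; beyond the scatter)). The other two steps are also modest and beyond the scatter (a 2.8-fold higher number from compound 2 to compound 4 (0.45 log units; beyond the scatter) and a 2.8-fold higher number from compound 3 to compound 4 (0.45 log units; beyond the scatter)). Among these four compounds, then, the position accepts three different rings with no readable difference but does respond to 2-methylphenyl, and nothing available explains why.

On these data alone, it remains open whether 2-fluorophenyl or 2-methoxyphenyl would read like phenyl or like 2-methylphenyl. It also remains open whether 4-methylphenyl would give the same result, so the compounds shown cannot separate the presence of the methyl group from its place on the ring.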